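The source may hold more compounds than are shown below. What is called first, only, known or untested is meant among the compounds shown, and "the series" means these compounds.

In a physicochemical assay for solubility, measured as kinetic solubility (a higher number here means a more soluble compound, a lower number a less soluble compound), compound 1 `Cc1cc(C)c(CN2CCc3c(Cl)cc([C@H](CO)[C@H]4CCOC4)c(Cl)c3C2=O)c(=O)[nH]1` gives 570000 nM, from a single entry. Compound 2 `COC(c1cc(Cl)c2c(c1Cl)C(=O)N(Cc1c(C)cc(C)[nH]c1=O)CC2)C1CCOC1` gives 415000 nM; 457000 nM; 439000 nM; 436000 nM (4 entries) over repeated entries, and compound 3 `Cc1cc(C)c(CN2CCc3c(Cl)cc(C(CO)c4ccon4)c(Cl)c3C2=O)c(=O)[nH]1` gives 596000 nM; 481000 nM (2 entries), also repeated. These three values lie within the usual scatter of one another, so compound 1 takes no rank among them. Compound 4 `Cc1cc(C)c(CN2CCc3c(Cl)cc([C@H](CO)[C@@H]4CCCO4)c(Cl)c3C2=O)c(=O)[nH]1` keeps the core of compound 1 and differs by oxolan-2-yl in place of oxolan-3-yl on a saturated chain carbon bound to an aromatic carbon and a saturated chain carbon. Going by the values given here, no measured pair isolates this change, and no step beyond the scatter is expected in this assay, in either direction. The expected change is a 1.1-fold lower number from compound 1 to compound 4 (0.06 log units; within the scatter). For compound 4 the estimated value is 500000 nM, with an expected range of 280000 nM to 800000 nM.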

Compound 4, solubility: 400000 nM
Compound 4: middle estimate off by 1.3-fold (0.10 log units), on the high side; the measured number falls inside the stated range.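

In this assay, oxolan-2-yl in place of oxolan-3-yl on this saturated chain carbon gives a 1.4-fold lower number from compound 1 to compound 4 (0.15 log units; within the scatter). Going by these compounds alone, this is the first step that can be read at this position, and it does not separate the two ring attachments. Repeat entries of a single compound also differ: the several entries of compound 3 in this assay, 596000 nM; 481000 nM (2 entries)

On these data alone, whether any group on this carbon gives a step beyond the scatter remains open. An amine or a carboxylic acid in place of the oxolanyl ring would test this.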